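Swapping Iodo for Methyl in a Growth Inhibitor

The source may hold more compounds than are shown below. What is called first, only, known or untested is meant among the compounds shown, and "the series" means these compounds.

Compound 1 `NC(=O)c1ccccc1NC(=O)COc1ccc(Cl)cc1Cl`: < 10% (a limit)
Compound 2 `NC(=O)c1cc(I)ccc1NC(=O)COc1ccc(Cl)cc1Cl`: 74.7%

In a functional assay on K562 cells (Homo sapiens) for inhibition, read by trypan blue exclusion, with a stated time of 24 h, tested at 10 uM (on this read-out higher numbers stand for more inhibition of growth at the one concentration tested and lower numbers for less inhibition of growth), compound 1 gives < 10%, which is a limit of the assay and not a number. Within the data shown here, compound 2, at 74.7%, holds the only true number so far. Compound 3 `Cc1ccc(NC(=O)COc2ccc(Cl)cc2Cl)c(C(N)=O)c1` differs from it as follows: methyl in place of iodo on an aromatic carbon; that is, methyl in place of iodo on an aromatic carbon. Among the measured compounds shown here, one measured step bears on this, and it is large: a number at least 64.7 percentage points higher from compound 1 to compound 2 (beyond the scatter). It put iodo where hydrogen stood, at the same place. Methyl is neither of these, so only part of that gain is expected to remain. The expected change in this assay is a number 39.7 percentage points lower from compound 2 to compound 3 (beyond the scatter), a fall beyond the scatter. The estimate for compound 3 is 35%, within a range of 12% to 65%.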

Compound 3, percent growth inhibition at one concentration: 35.4%
Compound 3: the middle estimate sits 0.4 percentage points below what was measured; measured number inside the range.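

In this assay, methyl at this position also brings a gain over hydrogen, with a number at least 25.4 percentage points higher from compound 1 to compound 3 (beyond the scatter), so the gain seen with iodo is not iodo's alone. Any group here is not as good as any other, though: each of these two groups is a single heavy atom, yet the swap gives a number 39.3 percentage points lower from compound 2 to compound 3 (beyond the scatter). The value of compound 1 is a limit of the assay and not a number: the limit of < 10% in this assay, at which 1 of the 3 values shown sits.

On these data alone, what separates iodo from methyl remains open, as does how a chlorine, an amine or a carboxylic acid would fare at this position.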